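Methyl on the aryl ring: one measured step, one pending

A few compounds are considered here, and "the series" means these few. Any claim that something is new, unique, unknown or untested is made for them only; others in the source may bear on it.

Measured compounds:
compound 1 `CC(=O)c1c(NNc2ccccc2)cc(C)oc1=O`: 52%
compound 2 `CC(=O)c1c(NNc2ccc(C)cc2)cc(C)oc1=O`: 50%
compound 3 `Cc1cc2nn(-c3ccccc3)c(C)c2c(=O)o1`: 43.1%

The series has been run in a functional assay on the whole organism for inhibition, with Rattus norvegicus as the target, read by paw edema, with a stated time of 4 h, at a dose of 50 mg/kg; a higher number here means more inhibition at the dose given (going by the name of the read-out), a lower number less inhibition. Compound 1 gives 52% there, and compound 2 gives 50%. The change between them is methyl in place of hydrogen on an aromatic carbon; the step it made is a number 2 percentage points lower from compound 1 to compound 2 (within the scatter), so the two values are not separated by this assay.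

Compound 3 is built on a different core. Its value of 43.1% lies within the scatter of both compound 1 and compound 2, so nothing separates the three measured compounds here. The difference between the core of compound 3 and the core of compound 1 is not broken down here.

Compound 4 `Cc1ccc(-n2nc3cc(C)oc(=O)c3c2C)cc1` is not yet measured. It differs from compound 3 by methyl in place of hydrogen on an aromatic carbon, the same change as from compound 1 to compound 2, at the same kind of place on the ring. Because the earlier step was a number 2 percentage points lower from compound 1 to compound 2 (within the scatter), the expected step is likewise small, a number 1.1 percentage points lower from compound 3 to compound 4 (within the scatter). Compound 4 is therefore estimated at 42%, with a range of 30% to 54% expected from the scatter.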

Compound 4, a percentage reported as inhibition, in the whole organism at one dose (the size of the read-out at that dose, not a potency): 41.7%
Compound 4: the middle estimate sits 0.3 percentage points above what was measured; measured number inside the range.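

Methyl in place of hydrogen on an aromatic carbon gives, in this assay, a number 1.4 percentage points lower from compound 3 to compound 4 (within the scatter). Set beside the earlier step, the change reads alike on both cores: the same change on two cores in this assay, a number 2 percentage points lower (within the scatter) from compound 1 to compound 2 and a number 1.4 percentage points lower (within the scatter) from compound 3 to compound 4, 0.6 percentage points apart, within the scatter of two such steps

So within these two pairs the change carries from one core to the other without a difference that this assay can separate, but both steps lie within the scatter, so neither pair shows that methyl moves the inhibition on its own core, and two pairs at one dose and one time say nothing about any further core.

The compounds shown hold only hydrogen or methyl at this place on the aryl ring, so whether a chlorine, a methoxy group, an amine or a carboxylic acid there would give a step that stands clear of the scatter remains open on both cores. Also open, on these data alone, is whether a longer chain in place of the methyl would read alike on the two cores.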